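A few compounds are considered here, and "the series" means these few. Any claim that something is new, unique, unknown or untested is made for them only; others in the source may bear on it.

The measured compounds:
compound 1, `O=C1/C(=C/c2ccccc2F)CN(C(=S)SCc2cn(Cc3ccccc3Cl)nn2)C/C1=C\c1ccccc1F`; compound 2, `COc1ccc(/C=C2\CN(C(=S)SCc3cn(Cc4cccc(Cl)c4)nn3)C/C(=C\c3ccc(OC)cc3)C2=O)cc1`; compound 3, `O=C1/C(=C/c2ccccc2F)CN(C(=S)SCc2cn(Cc3cccc(Cl)c3)nn2)C/C1=C\c1ccccc1F`.

In a functional assay on DU-145 cells (Homo sapiens) for cytotoxicity, read by MTT assay, with a stated time of 24 h (a lower number here means a stronger inhibitor, a higher number a weaker inhibitor), compound 1 gives 46300 nM. For compound 2 only a limit of the assay is known, namely > 80000 nM. For compound 3 likewise only a limit of the assay is known, namely > 80000 nM. Two of the three values thus sit at the limit of > 80000 nM in this assay, at which 2 of the 3 values shown sit, which leaves a thin basis for comparison.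

Compound 1 and compound 3 differ in one place: 2-chlorophenyl in place of 3-chlorophenyl on a saturated chain carbon bound to an aromatic nitrogen. In this assay that change gave an at least 1.7-fold lower number from compound 3 to compound 1 (0.23 log units; that floor lies within the scatter), a step whose floor lies within the usual scatter.

Compound 4, `COc1ccc(/C=C2\CN(C(=S)SCc3cn(Cc4ccccc4Cl)nn3)C/C(=C\c3ccc(OC)cc3)C2=O)cc1`, has not yet been measured. It stands to compound 2 as compound 1 stands to compound 3, with the same change in the same place: 2-chlorophenyl in place of 3-chlorophenyl on a saturated chain carbon bound to an aromatic nitrogen. The difference between the core of compound 2 and the core of compound 3 is not broken down here.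

The expected step from compound 2 to compound 4 in this assay is an at least 1.3-fold lower number from compound 2 to compound 4 (0.12 log units; that floor lies within the scatter), placed beside the earlier one. This rests only on the step of an at least 1.7-fold lower number from compound 3 to compound 1 (0.23 log units; that floor lies within the scatter), which is a floor and small, and on compound 2 being known only as a limit. Compound 4 is therefore expected to give about 60000 nM, within 30000 nM to 150000 nM, with a real chance that only a limit is reported again.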

Compound 4, half-maximal inhibitory concentration: > 80000 nM
Compound 4: no number, only a limit; the forecaster's own chance of this, stated with the estimate: 50%; middle value at least 1.3-fold (0.12 log units) away from the limit.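

No step from compound 2 to compound 4 can be read, since each of the two is known only as a limit and not as a number in this assay: the limit of > 80000 nM in this assay, at which 3 of the 4 values shown sit.

As far as these compounds go, what stays open is whether 2-chlorophenyl in place of 3-chlorophenyl changes the number at all on the core of compound 2, and whether the change seen from compound 3 to compound 1 is real, since its floor lies within the usual scatter.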